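A few compounds are considered here, and "the series" means these few. Any claim that something is new, unique, unknown or untested is made for them only; others in the source may bear on it.

Measured so far in a functional assay on the whole organism for antagonist activity, with Mus musculus as the target; on this read-out lower numbers stand for an effect already at smaller amounts and higher numbers for an effect only at larger amounts of compound:
Compound 1 `COc1cc(N)c(Cl)cc1NC(=O)C1CCN(Cc2ccc(Cl)cc2)CC1`: compound 1 gives 1.2 mg/kg.
Compound 2 `COc1cc(N)c(Cl)cc1NC(=O)C1CCN(CC2CCC2)CC1`: compound 2 gives only a limit of the assay, > 10 mg/kg.
Compound 3 `COc1cc(N)c(Cl)cc1NC(=O)C1CCN(Cc2ccc([N+](=O)[O-])cc2)CC1`: compound 3 gives only a limit of the assay, > 4 mg/kg.

Compound 3 therefore stands on no number but on a limit, and among the three values shown it is not alone in that: the limit of > 10 mg/kg in this assay, at which 1 of the 3 values shown sits, and the limit of > 4 mg/kg in this assay, at which 1 of the 3 values shown sits, together make up two of the three entries. Compound 4 `CCN1CCC(C(=O)Nc2cc(Cl)c(N)cc2OC)CC1` differs from compound 3 in one place: methyl in place of 4-nitrophenyl on a saturated chain carbon bound to an amine nitrogen in a ring. For the measured compounds named here, two measured steps bear on this change. The step of an at least 8.3-fold higher number from compound 1 to compound 2 (0.92 log units; beyond the scatter) shows that exchanging the 4-chlorophenyl group for a small saturated ring on that chain carbon already pushed the dose beyond what the assay could read. The step of an at least 3.3-fold higher number from compound 1 to compound 3 (0.52 log units; beyond the scatter) shows that the nitro compound itself sits only at a limit. The step that the two limits leave unreadable from compound 2 to compound 3 cannot be read from its two limits. A methyl group is smaller still than cyclobutyl, so compound 4 is expected to sit at or beyond the same limits: the expected step that the limit leaves unreadable from compound 3 to compound 4 is small, and the estimated dose for compound 4 is 10 mg/kg, within 3 mg/kg to 30 mg/kg.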

Compound 4, dose for half-maximal effect: > 10 mg/kg
Compound 4 ended at the assay's limit; the forecaster's own chance of this, stated with the estimate: 60%; the middle value sits exactly at the limit.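

In this assay, methyl in place of 4-chlorophenyl gives an at least 8.3-fold higher number from compound 1 to compound 4 (0.92 log units; beyond the scatter), so the small saturated groups shown, cyclobutyl and now methyl, both lose the readable dose that the 4-chlorophenyl group gave. The value of compound 4 is a limit and not a number, and it is the same limit that compound 2 gives: the limit of > 10 mg/kg in this assay, at which 2 of the 4 values shown sit.

The steps from compound 3 to compound 4 and from compound 2 to compound 4 cannot be read, as both ends of each are limits, and so methyl stands in no order against cyclobutyl or 4-nitrophenyl.

For the compounds shown here, compound 1 remains the only compound here with a number, which leaves open how far that number depends on the chloro group. An unsubstituted phenyl or a 4-fluorophenyl at this place would bear on that, and a longer chain would show whether a saturated group of greater length can return a number.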